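Amidoxime linker variation on the shared core, cytotoxicity notes

The source may hold more compounds than are shown below. What is called first, only, known or untested is meant among the compounds shown, and "the series" means these compounds.

Compound 2 `CC1(Cc2ccccc2)CC(S(=O)(=O)c2ccc(/C(N)=N/O)cc2)=C(c2ccc(Nc3ccccc3/C(N)=N/O)cc2)O1` carries the shared core also present in compound 1 `CC1(Cc2ccccc2)CC(S(=O)(=O)c2ccc(/C(N)=N/O)cc2)=C(c2ccc(Nc3ccc(/C(N)=N/O)cc3)cc2)O1`. Going by the values given here, in an ADME assay on THP-1 cells (Homo sapiens) for cytotoxicity, read by flow cytometry, with a stated time of 72 h (a higher number here means a weaker inhibitor, a lower number a stronger inhibitor), compound 2 gives 48100 nM, the highest of the two numbers measured, while compound 1 gives 9800 nM; the single step recorded, a 4.9-fold higher number from compound 1 to compound 2 (0.69 log units; beyond the scatter), is modest but clearly beyond the scatter.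

Compound 3 `CC1(Cc2ccccc2)CC(S(=O)(=O)c2ccc(/C(N)=N/O)cc2)=C(c2ccc(/C=C/c3ccc(/C(N)=N/O)cc3)cc2)O1` is the next member. The change from compound 2 is a group of 12 heavy atoms (9 carbon, 2 nitrogen, 1 oxygen; one six-membered aromatic ring of carbon only) in place of a group of 11 heavy atoms (7 carbon, 3 nitrogen, 1 oxygen; one six-membered aromatic ring of carbon only), on an aromatic carbon, with the new group sitting para to a large group on that ring, as in compound 1. Among the compounds with values here, no measured step covers this exact exchange; the only step that bears on it, a 4.9-fold higher number from compound 1 to compound 2 (0.69 log units; beyond the scatter), shows that rearranging the group on this side of the core moves this assay by a modest amount, so a shift of similar size, in the lowering direction back toward compound 1, is the working expectation rather than no change. Compound 3 is therefore estimated at 12000 nM in this assay, with a range of 4000 nM to 40000 nM, which corresponds to an expected step of a 4.0-fold lower number from compound 2 to compound 3 (0.60 log units; beyond the scatter).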

Compound 3, half-maximal inhibitory concentration: 23400 nM
Beside the measured number, compound 3's estimate is 2.0-fold (0.29 log units) below it; the measured number falls inside the stated range.
By their numbers in this assay, from the lowest: compound 1; then compound 3; then compound 2.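

Position notes: the group para to a large group on the ring now has a second kind of change behind it, since compound 1 and compound 3 keep that placement and exchange the nitrogen-linked group for the carbon-linked group with 2 double bonds outside aromatic rings. In this assay, that exchange gives a 2.4-fold higher number from compound 1 to compound 3 (0.38 log units; beyond the scatter), so the number at this position does not depend on placement alone. The other comparison, a 2.1-fold lower number from compound 2 to compound 3 (0.31 log units; beyond the scatter), puts compound 3 in the middle of the three numbers, and no evidence is at hand to explain either step.

Still open, from the compounds shown here alone, is how far this trend holds for other links at the same place, such as an amide or a longer chain, since only one nitrogen link and one carbon link with this placement can be compared here. Also open, going by these compounds, is whether a carboxylic acid in place of the amidoxime on this side would move this assay in either direction, or whether these steps are specific to the amidoxime.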